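A fluoro added to the chloro compound

This account rests on a few compounds, and the source may have more. Where it says the series, first, only, none or still open, it means among the compounds named here.

Compound 1 `CCOC(=O)c1c(-c2cccc(OC)c2)[nH]c2cc(OC)ccc2c1=O`: 74000 nM
Compound 2 `CCOC(=O)c1c(-c2cccc(Cl)c2)[nH]c2cc(OC)ccc2c1=O`: 58000 nM

Going by the values given here, in a physicochemical assay for solubility, at pH 7.4 (on this read-out lower numbers stand for lower solubility and higher numbers for higher solubility), compound 2 stands at 58000 nM, within the scatter of compound 1, the only other measured compound. Compound 3 `CCOC(=O)c1c(-c2cccc(Cl)c2)[nH]c2cc(OC)c(F)cc2c1=O` carries fluoro in place of hydrogen on an aromatic carbon, ortho to a methoxy group (fluoro in place of hydrogen on an aromatic carbon). Among the compounds with values here, the one measured step, a 1.3-fold lower number from compound 1 to compound 2 (0.11 log units; within the scatter), concerns a different change and is small, and no measured step adds a fluoro. No step beyond the scatter is therefore expected in this assay, and the estimated step is a 1.2-fold lower number from compound 2 to compound 3 (0.06 log units; within the scatter). Compound 3 is expected at 50000 nM, with an estimated range from 20000 nM to 100000 nM.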

Compound 3, solubility: 20000 nM
Compound 3: the middle estimate sits 2.5-fold (0.40 log units) above what was measured; the range from low to high includes it.
By their numbers in this assay, from the lowest: compound 3; then compounds 2 and 1 (each within the scatter of the next).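

In this assay, fluoro in place of hydrogen on an aromatic carbon, ortho to a methoxy group, gives a 2.9-fold lower number from compound 2 to compound 3 (0.46 log units; beyond the scatter), a step beyond the scatter, while a 1.3-fold lower number from compound 1 to compound 2 (0.11 log units; within the scatter) stayed within it. This position of the shared core therefore responds measurably to the entry of a single fluorine atom. Nothing at hand explains the lower number. The compounds shown leave open whether a chloro, an amine or a carboxylic acid at this position would move the number the same way. They also leave open whether fluoro here would have a similar effect with the methoxy group of compound 1 in place of the chloro.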